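The compounds below may be only part of what the source reports. "The series", "measured", "known", "first", "only" and "open" are said of these compounds alone.

Compound 1 `O=C(Nc1nc2ccccc2[nH]1)[C@H]1C[C@@H]1c1cccc(F)c1` is the stronger of the two compounds measured in an assay on BV-2 cells for positive allosteric modulation of metabotropic glutamate receptor 5 (Mus musculus), read by Griess assay, with stated times of 1 h and 24 h; a lower number here means a stronger inhibitor, a higher number a weaker inhibitor: compound 1 gives 21000 nM, while compound 2 `O=C(Nc1ccc(F)cc1)[C@H]1C[C@@H]1c1cccc(Cl)c1` gives 58000 nM, a gap beyond the scatter. Compound 2 differs from compound 1 in more than one place at once, so its value shows only what those changes do together, not what any one of them does alone.

Compound 3 `O=C(Nc1nc2ccccc2[nH]1)[C@H]1C[C@@H]1c1cccc(Cl)c1` is the compound still to be measured. It differs from compound 1 by chloro in place of fluoro on an aromatic carbon, so that the 3-fluorophenyl of compound 1 becomes a 3-chlorophenyl. Among the measured compounds shown here, no measured pair shows this single change on its own, and the shared core with its amide is kept. The step of a 1.2-fold higher number from compound 1 to compound 3 (0.08 log units; within the scatter) is expected to stay within the scatter, in no clear direction. For compound 3 the expected value in this assay is 25000 nM, with a range from 10000 nM to 60000 nM.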

Compound 3, half-maximal inhibitory concentration: 67000 nM
Beside the measured number, compound 3's estimate is 2.7-fold (0.43 log units) below it; measured number above the stated range.
By their numbers in this assay, from the lowest: compound 1; then compounds 2 and 3 (each within the scatter of the next).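

In this assay, the halogen on this aromatic carbon, meta to a large group, turns out to matter: with the shared core and its amide kept, chloro in place of fluoro gives a 3.2-fold higher number from compound 1 to compound 3 (0.50 log units; beyond the scatter) and so costs a modest but real amount of inhibition, the first effect of a single change seen in this series. The result also changes the picture on the amide side, since with the 3-chlorophenyl held constant, compound 2 at 58000 nM and compound 3 at 67000 nM lie within the scatter of each other, so these two amide partners are not told apart by this read-out. No evidence is available on why fluoro and chloro differ at this position.

Going by these compounds, with only two halogens compared at one position, it remains open whether a hydrogen, a methyl, a methoxy or a trifluoromethyl here would follow fluoro or chloro, or go beyond both. On these data alone, it is also open whether the fluoro-to-chloro step keeps its size with the other amide partner, as the 3-fluorophenyl has been seen with only one of the two.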